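This account rests on a few compounds, and the source may have more. Where it says the series, first, only, none or still open, it means among the compounds named here.

Series notes on the shared core in a functional assay on UACC-62 cells (Homo sapiens) for inhibition, read by sulforhodamine B assay, with a stated time of 48 h, tested at 10 uM; on this read-out higher numbers stand for more inhibition at the one concentration tested (going by the name of the read-out) and lower numbers for less inhibition. Compound 1 `Brc1cn2ccnc2c(-c2ccc3ncn(C4CCCCC4)c3c2)n1` gives 19.8%. Compound 2 `COc1ccc(-c2cn3ccnc3c(-c3ccc4ncn(C5CCCCC5)c4c3)n2)cc1` gives 65.2%. Compound 3 `c1ccc2c(-c3cn4ccnc4c(-c4ccc5ncn(C6CCCCC6)c5c4)n3)cccc2c1` gives 16.7%, the lowest of the three numbers, though its gap to compound 1 is within the scatter; only compound 2 stands clearly above it.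

Compound 4 `Clc1ccc(-c2cn3ccnc3c(-c3ccc4ncn(C5CCCCC5)c4c3)n2)cc1` is not yet measured. It differs from compound 3 in one place: 4-chlorophenyl in place of naphthalen-1-yl on an aromatic carbon. The bearing steps are a number 48.5 percentage points lower from compound 2 to compound 3 (beyond the scatter) and a number 45.4 percentage points higher from compound 1 to compound 2 (beyond the scatter), both involving a 4-methoxyphenyl group rather than a 4-chlorophenyl, so the match is by analogy only; the third step, a number 3.1 percentage points lower from compound 1 to compound 3 (within the scatter), shows naphthalen-1-yl and bromo at about the same level. Since the change from compound 3 to compound 4 reverses the naphthalen-1-yl step in kind, a large rise in this assay is expected, with a wide range to allow for the untested chlorine. For compound 4 the estimate is 50%, between 25% and 75%. The expected step is a number 33.3 percentage points higher from compound 3 to compound 4 (beyond the scatter).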

Compound 4, a percentage reported as inhibition, at one concentration (the size of the read-out at that concentration, not a potency): 30.5%
For compound 4 the middle estimate is 19.5 percentage points above the measured one, and the stated range covers the measured number.
By their numbers in this assay, from the lowest: compounds 3 and 1 (each within the scatter of the next); then compound 4; then compound 2.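

In this assay, the aryl group at this position does not by itself carry the level of compound 2, since the step of a number 34.7 percentage points lower from compound 2 to compound 4 (beyond the scatter) comes from exchanging methoxy for chloro on the same phenyl ring. The 4-chlorophenyl group still separates modestly from the other two groups, with a number 13.8 percentage points higher from compound 3 to compound 4 (beyond the scatter) and a number 10.7 percentage points higher from compound 1 to compound 4 (beyond the scatter) as the steps, so the substituent on the phenyl ring sets how much of the rise appears. No measurement in hand bears on why these groups differ.

Open, going by these compounds, is whether the level of compound 2 is particular to methoxy or is shared by a hydroxyl, an amine or an ethoxy group on the phenyl ring. Also open, on these data alone, is where a plain phenyl group would fall relative to compound 2 and compound 4.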